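The source may report more compounds than this note shows. Statements on the series, on what has been measured and on what is new or still open speak of the compounds shown alone.

In an ADME assay on microsomes from liver (Rattus norvegicus) for metabolic stability, read by mass spectrometry, with a stated time of 10 min, tested at 0.5 uM (a lower number here means that less of the compound is left, a higher number that more of the compound is left), compound 1 (`NC(=O)c1cnc2c(NC3CC3)cc(Nc3cccc(-c4ccc(C(F)(F)F)cc4F)c3)nn12`) gives 86% while compound 2 (`CNc1cc(Nc2cc(C)cc(C)c2)nn2c(C(N)=O)cnc12`) gives 21% and so holds the lower of the two numbers, with a gap beyond the scatter. Compound 3 (`CNc1cc(Nc2cc(C)cc(C)c2)nn2c(C(=O)NCC(C)(C)CO)cnc12`) departs from compound 2 at a single place. The change is 2-(hydroxymethyl)-2-methylpropyl in place of hydrogen on an amide-type nitrogen and reads in words as 2-(hydroxymethyl)-2-methylpropyl in place of hydrogen on an amide-type nitrogen. Among the compounds with values here, no measured pair shows this change, so only an estimate is possible: an expected a number 1 percentage points lower from compound 2 to compound 3 (within the scatter) that stays within the scatter. In this assay compound 3 is estimated at 20% with a range of 5% to 45% expected for it.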

Compound 3, percent of the compound remaining: 4%
Beside the measured number, compound 3's estimate is 16 percentage points above it, outside the stated range (below it).
By their numbers in this assay, from the lowest: compound 3; then compound 2; then compound 1.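

In this assay, the amide nitrogen proves responsive to substitution: 2-(hydroxymethyl)-2-methylpropyl in place of the amide hydrogen gives a number 17 percentage points lower from compound 2 to compound 3 (beyond the scatter) and takes an already low number lower still. This single change therefore does not close the gap to compound 1, although the two differ elsewhere too. Nothing shown here explains the drop. Still open, going by these compounds, is whether the terminal hydroxyl or the branched carbon chain carries the step, and how a plain methyl group or a longer unbranched chain would read on the same nitrogen.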